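The source may report more compounds than this note shows. Statements on the series, on what has been measured and on what is new or still open speak of the compounds shown alone.

In a physicochemical assay for solubility, read by spectrophotometry, in phosphate buffer, with a stated time of 18 h, at pH 7.4 (on this read-out higher numbers stand for higher solubility and lower numbers for lower solubility), compound 2 `Cc1ccccc1-c1nc2c(c(C)nn2-c2ccccc2)c(-c2ccccc2O)c1C#N` gives 21000 nM, which is the higher of the two numbers obtained so far. Within the data shown here, the only other measured compound, compound 1 `CCc1ccc(-c2nc3c(c(C)nn3-c3ccccc3)c(-c3ccccc3F)c2C#N)cc1`, gives 1700 nM in this assay, and the gap between these two values lies beyond the usual scatter of repeated measurements. Compound 3 `Cc1nn(-c2ccccc2)c2nc(-c3ccc4c(c3)CCCC4)c(C#N)c(-c3ccccc3O)c12` has not yet been measured. It differs from compound 2 in a single place: 1,2,3,4-tetrahydronaphthalen-6-yl in place of 2-methylphenyl on an aromatic carbon. Among the measured compounds shown here, no pair of measured compounds differs by just one change, so there is no measured step to lean on, and the expectation rests on the bare fact that a larger hydrocarbon group replaces a smaller one. The expected step of a 3.5-fold lower number from compound 2 to compound 3 (0.54 log units; beyond the scatter) is a moderate fall in solubility, probably somewhat beyond the scatter. Compound 3 is therefore expected to give about 6000 nM, with a plausible range from 1500 nM to 20000 nM.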

Compound 3, solubility: 13000 nM
Compound 3: middle estimate off by 2.2-fold (0.34 log units), on the low side; the range from low to high includes it.
By their numbers in this assay, from the lowest: compound 1; then compounds 3 and 2 (each within the scatter of the next).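

Replacing 2-methylphenyl with 1,2,3,4-tetrahydronaphthalen-6-yl, on the aromatic carbon next to the ring nitrogen and ortho to the cyano group, gives a 1.6-fold lower number from compound 2 to compound 3 (0.21 log units; within the scatter) in this assay for this pair. Among these compounds, this is the first single-place comparison, and it shows that this position accepts a carbon-only group of 10 heavy atoms in place of one of 7 with no change that can be told apart from measurement scatter. Nothing available here explains why the two compounds read alike.

On these data alone, whether the same position would tolerate a group of another kind, such as an amine, a carboxylic acid or a longer chain, remains open. Compound 1 differs from compounds 2 and 3 in more than one place, so no single change can be read from it.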